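A few compounds are considered here, and "the series" means these few. Any claim that something is new, unique, unknown or untested is made for them only; others in the source may bear on it.

Working notes on the series, read in a functional assay on NCI-H661 cells (Homo sapiens) for antiproliferative activity, read by MTT assay, with a stated time of 72 h; on this read-out higher numbers stand for weaker inhibition of growth and lower numbers for stronger inhibition of growth.

Compound 1, `COc1ccc(NC(=O)COc2ccc3oc(-c4ccccc4)cc(=O)c3c2)cc1`, is the reference point; in this assay compound 1 gives 840 nM. Compound 2, `O=C(COc1ccc2oc(-c3ccccc3)cc(=O)c2c1)Nc1ccc(-c2ccccc2)cc1`, differs from it by one change, (phenyl in place of methoxy on an aromatic carbon), and in this assay compound 2 gives 9710 nM. For the measured compounds named here, the step of a 12-fold higher number from compound 1 to compound 2 (1.06 log units; beyond the scatter) is the only measured instance of this change so far.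

Compound 3, `COc1ccc(NC(=O)COc2ccc3c(=O)c(-c4ccccc4)coc3c2)cc1`, carries the same substituents on a core built from the same atoms joined differently; how the two cores differ is not broken down here. In this assay compound 3 gives 9530 nM, and its values and those of compound 2 lie within the scatter of each other, while compound 1 stands apart from both.

Compound 4, `O=C(COc1ccc2c(=O)c(-c3ccccc3)coc2c1)Nc1ccc(-c2ccccc2)cc1`, is not yet measured. It differs from compound 3 by phenyl in place of methoxy on an aromatic carbon, the same change as from compound 1 to compound 2, at the same place. The step of a 3.1-fold higher number from compound 3 to compound 4 (0.50 log units; beyond the scatter) is expected to be smaller than the measured one, because compound 3 starts from 9530 nM and a repeat of the full step would run toward the edge of the measurable range. Compound 4 is estimated at 30000 nM, expected between 8000 nM and 100000 nM.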

Compound 4, concentration for 50% growth inhibition: > 10000 nM
Compound 4: only a limit was reported; the forecaster's own chance of this, stated with the estimate: 25%; the middle value does not contradict the limit.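

Compound 4 gives > 10000 nM in this assay, which is a limit of the assay and not a number. On the core of compound 3, phenyl in place of methoxy therefore reads only as a floor, an at least 1.0-fold higher number from compound 3 to compound 4 (0.02 log units; that floor lies within the scatter), and that floor alone does not establish a weakening of growth inhibition on this core, although it does not exclude one as large as that on the core of compound 1. Whether the change carries from one core to the other with the same size stays undecided, and the two compounds pairs show neither a match nor a mismatch: the same change on two cores in this assay, a 12-fold higher number (1.06 log units; beyond the scatter) from compound 1 to compound 2 and an at least 1.0-fold higher number (0.02 log units; that floor lies within the scatter) from compound 3 to compound 4; the limit leaves it open whether they differ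

The series shown compares only methoxy and phenyl at this place on the two cores, so it remains open how an amine or a carboxylic acid there would read on each core. Also open, going by these compounds, is whether a longer chain in place of methoxy would give steps on both cores that stay clear of the limit and can be compared directly.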